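Furan-3-yl for Iodo on a Second Nucleoside Core

The compounds below may be only part of what the source reports. "The series", "measured", "known", "first", "only" and "open" are said of these compounds alone.

Three nucleoside analogues have been measured in a functional assay on HeLa S3 cells (Homo sapiens) for antiproliferative activity, read by XTT assay, with a stated time of 72 h; on this read-out lower numbers stand for stronger inhibition and higher numbers for weaker inhibition. Compound 1 `Cc1ncnc2c1c(I)cn2[C@@H]1O[C@H](CO)[C@@H](O)[C@H]1O` carries an iodo group and gives 4080 nM. Compound 2 `Cc1ncnc2c1c(-c1ccoc1)cn2[C@@H]1O[C@H](CO)[C@@H](O)[C@H]1O` differs from compound 1 by furan-3-yl in place of iodo on an aromatic carbon. In this assay compound 2 reaches only > 20000 nM, which is a limit of the assay and not a number. The change brought an at least 4.9-fold higher number from compound 1 to compound 2 (0.69 log units; beyond the scatter), and the size of this step rests on (the limit of > 20000 nM in this assay, at which 1 of the 3 values shown sits).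

Compound 3 `Cc1nc(N)c2c(I)cn([C@@H]3O[C@H](CO)[C@@H](O)[C@H]3O)c2n1` has another core; the difference between the core of compound 1 and that of compound 3 is not broken down here. In this assay compound 3 gives 4180 nM, a value that sits within the scatter of the value of compound 1.

Compound 4 `Cc1nc(N)c2c(-c3ccoc3)cn([C@@H]3O[C@H](CO)[C@@H](O)[C@H]3O)c2n1` has not yet been measured. It differs from compound 3 by furan-3-yl in place of iodo on an aromatic carbon, the same change that separates compound 2 from compound 1, at the same place. For compound 4 the step from compound 3 is expected to be a 7.2-fold higher number from compound 3 to compound 4 (0.86 log units; beyond the scatter), because the same change gave an at least 4.9-fold higher number from compound 1 to compound 2 (0.69 log units; beyond the scatter). Since the value of compound 2 is only a limit, the result for compound 4 is also expected to end as a limit rather than a number. Compound 4 is therefore estimated at 30000 nM in this assay, between 12000 nM and 80000 nM.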

Compound 4, half-maximal inhibitory concentration: > 20000 nM
Compound 4: only a limit was reported; the forecaster's own chance of this, stated with the estimate: 75%; the middle value is on the limit's open side.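

In this assay compound 4 gives > 20000 nM, which is a limit of the assay and not a number. Furan-3-yl in place of iodo on the second core gave an at least 4.7-fold higher number from compound 3 to compound 4 (0.67 log units; beyond the scatter), so on both cores shown the change moved the number the same way, towards weaker inhibition, and the two steps can be set side by side: the same change on two cores in this assay, an at least 4.9-fold higher number (0.69 log units; beyond the scatter) from compound 1 to compound 2 and an at least 4.7-fold higher number (0.67 log units; beyond the scatter) from compound 3 to compound 4; the limit leaves it open whether they differ. What this does not show is the true size of either step, or whether the change costs more on one core than on the other, because neither step ends on a number: the limit of > 20000 nM in this assay, at which 2 of the 4 values shown sit.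

The compounds shown leave open whether the weaker inhibition goes with furan-3-yl in particular or would also follow from other groups in place of iodo on this aromatic carbon, such as a thiophen-3-yl ring, a methyl group or an amine. They also leave open whether the same direction would hold on any core other than these two, since only one pair on each core is shown here and a group that stays measurable in this assay would be needed to put a number on the change.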